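The source may report more compounds than this note shows. Statements on the series, on what has been measured and on what is new or still open speak of the compounds shown alone.

Compound 3 `CCCCN1CCN(c2ccc(S(=O)(=O)Oc3ccc(OC)c(OC)c3)cc2)C1=O` carries a 3,4-dimethoxyphenyl on the sulfonyl oxygen, and in a functional assay on HT-29 cells (Homo sapiens) for antiproliferative activity, read by sulforhodamine B assay, with a stated time of 48 h (on this read-out lower numbers stand for stronger inhibition and higher numbers for weaker inhibition), compound 3 gives 21000 nM. Its nearest neighbour is compound 2 `CCCCN1CCN(c2ccc(S(=O)(=O)Oc3cccc(OC)c3)cc2)C1=O`, which in this assay gives 13000 nM; the step of a 1.6-fold higher number from compound 2 to compound 3 (0.21 log units; within the scatter) separates them, so neither can be ranked over the other. For compound 1 `CCCCN1CCN(c2ccc(S(=O)(=O)Oc3ccccc3OC)cc2)C1=O` the assay reports only a limit: compound 1 gives > 100000 nM, which is the limit of > 100000 nM in this assay, at which 1 of the 3 values shown sits. From that limit the steps of an at least 7.6-fold lower number from compound 1 to compound 2 (0.88 log units; beyond the scatter) and an at least 4.7-fold lower number from compound 1 to compound 3 (0.67 log units; beyond the scatter) show that exchanging the phenyl on the oxygen can shift the number at least modestly.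

Compound 4 `CCCCN1CCN(c2ccc(S(=O)(=O)Oc3ccc(F)c(F)c3)cc2)C1=O` differs from compound 3 in one place: 3,4-difluorophenyl in place of 3,4-dimethoxyphenyl on an oxygen. Among the measured compounds shown here, no measured step trades methoxy for fluorine; the only step that touches the same groups, a 1.6-fold higher number from compound 2 to compound 3 (0.21 log units; within the scatter), lies within the scatter, and the step of an at least 4.7-fold lower number from compound 1 to compound 3 (0.67 log units; beyond the scatter) starts from a limit and so cannot be sized. Near compound 3, then, compound 4 is expected to give 20000 nM, with a range from 5000 nM to 80000 nM. The implied step a 1.1-fold lower number from compound 3 to compound 4 (0.02 log units; within the scatter) is expected to stay within the scatter, though a limit remains possible.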

Compound 4, half-maximal inhibitory concentration: > 100000 nM
Compound 4: no number, only a limit; the forecaster's own chance of this, stated with the estimate: 15%; middle value at least 5.0-fold (0.69 log units) from the limit.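

In this assay, exchanging 3,4-dimethoxyphenyl for 3,4-difluorophenyl on the sulfonyl oxygen gives an at least 4.7-fold higher number from compound 3 to compound 4 (0.67 log units; beyond the scatter), so at this position the identity of the substituents can move the number, and not only where a methoxy stands. Among the compounds shown here, the comparison with the single methoxy group points the same way: an at least 7.6-fold higher number from compound 2 to compound 4 (0.88 log units; beyond the scatter). Compound 4, like compound 1, gives only a limit of the assay, so the step between those two cannot be read: the limit of > 100000 nM in this assay, at which 2 of the 4 values shown sit.

On these data alone, it remains open whether a single fluorine, as in 3-fluorophenyl, would behave like the 3,4-difluorophenyl group or like the 3-methoxyphenyl group. The compounds shown also leave open whether other groups on this phenyl, such as chlorine or an amine, would give a number rather than a limit.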